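A few compounds are considered here, and "the series" means these few. Any claim that something is new, unique, unknown or untested is made for them only; others in the source may bear on it.

Measured so far in an assay on liver for displacement of a labelled ligand from Sigma non-opioid intracellular receptor 1 (Cavia porcellus), read by scintillation counting, with a stated time of 1 h; on this read-out higher numbers stand for weaker inhibition and lower numbers for stronger inhibition:
compound 1 `CCCCN(CCCC)CCCc1ccc([N+](=O)[O-])cc1` gives 0.3 nM
compound 2 `CCCN(CCCc1ccc(F)cc1)Cc1ccc(N)cc1` gives 164 nM

Compound 2 has the higher of the two numbers, and its gap to compound 1 lies well beyond the scatter. Compound 3 `CCCN(CCCc1ccc(F)cc1)Cc1ccc(N)c(I)c1` differs from compound 2 by one change: iodo in place of hydrogen on an aromatic carbon, on an aromatic carbon ortho to an amino group. Among the measured compounds shown here, no measured pair shows what this change does here, so the expectation rests on compound 2 alone; a step of no more than the scatter is expected, if anything towards a lower number. For compound 3 the estimate is 110 nM, within 35 nM to 350 nM, meaning an expected step of a 1.5-fold lower number from compound 2 to compound 3 (0.17 log units; within the scatter).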

Compound 3, inhibition constant: 393000 nM
The estimate for compound 3 lay 3600-fold (3.55 log units) below the measured number, and the stated range ends below it.
By their numbers in this assay, from the lowest: compound 1; then compound 2; then compound 3.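

In this assay, iodo in place of hydrogen on the aromatic carbon ortho to the amino group gives a 2400-fold higher number from compound 2 to compound 3 (3.38 log units; beyond the scatter) and thus marks this position as highly sensitive to substitution in the core of compound 2. A single entering heavy atom, with no ring, no hydrogen-bond donor or acceptor and no net charge, is enough for this large loss. No available measurement explains the step.

As far as these compounds go, whether fluoro, chloro or methyl at this carbon would bring a smaller step remains open. Also open, from the compounds shown here alone, is whether iodo has the same effect when the amino group is replaced by a nitro group.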